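A Halogen Swap at the Edge of Measurable Activity

The source may hold more compounds than are shown below. What is called first, only, known or untested is meant among the compounds shown, and "the series" means these compounds.

Compound 1, `COc1ccc2c(=O)c(/C=C/C(=O)Nc3cc(C)ccc3C)coc2c1`: 58400 nM
Compound 2, `COc1ccc2c(=O)c(/C=C/C(=O)Nc3ccc(Cl)cc3)coc2c1`: > 100000 nM

Both compounds were examined in a functional assay on HeLa cells (Homo sapiens) for inhibition, read by MTT assay, with a stated time of 48 h; a higher number here means a weaker inhibitor, a lower number a stronger inhibitor. Compound 1, which carries a 2,5-dimethylphenyl on the amide-type nitrogen, gives 58400 nM. Compound 2 gives > 100000 nM, which is a limit of the assay and not a number. So compound 2 stands at the limit of > 100000 nM in this assay, at which 1 of the 2 values shown sits, the weak end of what this assay can report. For the measured compounds named here, the single measured step, an at least 1.7-fold higher number from compound 1 to compound 2 (0.23 log units; that floor lies within the scatter), exchanges the whole aryl group and its floor lies within the scatter, so it gives little guidance on size.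

Compound 3, `COc1ccc2c(=O)c(/C=C/C(=O)Nc3ccc(F)cc3)coc2c1`, differs from compound 2 by fluoro in place of chloro on an aromatic carbon. Going by the values given here, no measured step involves a halogen-for-halogen exchange, and the one step that exists concerns a different part of the molecule. The account therefore expects compound 3 to remain at or near the limit, with a number no higher from compound 2 to compound 3 (the limit leaves the size open) as the estimated step, meaning no change beyond the scatter. The estimate for compound 3 in this assay is 100000 nM, expected to fall between 40000 nM and 300000 nM.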

Compound 3, half-maximal inhibitory concentration: 9680 nM
Compound 3: middle estimate off by 10-fold (1.01 log units), on the high side, and the stated range ends above it.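

The position para to a large group on the anilide ring proves highly sensitive to the identity of the halogen: in this assay, fluoro in place of chloro gives an at least 10-fold lower number from compound 2 to compound 3 (1.01 log units; beyond the scatter), and this exchange of one heavy atom for another brings the series well inside the measurable range. Compound 2 carries a limit of the assay and not a number, so the size of this step is only a floor: the limit of > 100000 nM in this assay, at which 1 of the 3 values shown sits. The change of the whole aryl group on the amide-type nitrogen now also reads clearly, with 4-fluorophenyl in place of 2,5-dimethylphenyl giving a 6.0-fold lower number from compound 1 to compound 3 (0.78 log units; beyond the scatter), whereas the earlier step on that nitrogen had a floor within the scatter.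

Going by these compounds, whether a bromo, methoxy or amino group at the same position would follow compound 3 or compound 2 remains open. Also open, on these data alone, is how an unsubstituted phenyl, with hydrogen at that position, would compare, and therefore whether the gap between compound 2 and compound 3 reflects a gain with fluoro, a loss with chloro, or both.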